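From propyl to butyl on a saturated chain

This account rests on a few compounds, and the source may have more. Where it says the series, first, only, none or still open, it means among the compounds named here.

- compound 1 `C=C[C@@](C)(/C=C/c1ccc(OC(=O)CC)cc1)CCC=C(C)C`: 23%
- compound 2 `C=C[C@@](C)(/C=C/c1ccc(OC(=O)CCC)cc1)CCC=C(C)C`: 20%
- compound 3 `C=C[C@@](C)(/C=C/c1ccc(OC(=O)CCCC)cc1)CCC=C(C)C`: not yet measured

Among the compounds with values here, in a functional assay on MCF7 cells (Homo sapiens) for inhibition, with a stated time of 48 h, tested at 50 uM (on this read-out higher numbers stand for more inhibition of growth at the one concentration tested and lower numbers for less inhibition of growth), compound 2 gives 20%, and the only compound to compare it with is compound 1 at 23%. These two values lie within the usual scatter of each other.

Compound 3 differs from compound 2 by methyl in place of hydrogen on a saturated chain carbon, three bonds along the chain from a carbonyl carbon. In words, this is methyl in place of hydrogen on a saturated chain carbon, three bonds along the chain from a carbonyl carbon, which reads as propyl to butyl.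

Within the data shown here, one measured step bears on this. The same swap, two bonds along the chain from a carbonyl carbon, gave a number 3 percentage points lower from compound 1 to compound 2 (within the scatter). A single step of that size points in no firm direction, so no change beyond the scatter is expected in this assay. The expected step is a number 1 percentage points lower from compound 2 to compound 3 (within the scatter). For compound 3 the estimated value is 19%, with an expected range from 8% to 30%.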

Compound 3, percent growth inhibition at one concentration: 25%
Compound 3: the middle estimate sits 6 percentage points below what was measured; low and high end bracket the measured number.
By their numbers in this assay, from the lowest: compounds 2, 1 and 3 (each within the scatter of the next).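

In this assay, methyl in place of hydrogen three bonds along the chain from the carbonyl carbon, which reads as propyl to butyl, gives a number 5 percentage points higher from compound 2 to compound 3 (within the scatter), while ethyl in place of hydrogen two bonds along the chain gives a number 2 percentage points higher from compound 1 to compound 3 (within the scatter). Together with the earlier step, this shows that the chain can change across these three compounds with no step beyond the scatter, and the small steps follow no single direction. No measurement shown here offers an explanation for these numbers.

Going by these compounds, what stays open is whether a longer chain, such as octyl, would give a step beyond the scatter. It is equally open whether an amine or a carboxylic acid on this chain would do so, since all three chains shown are plain saturated carbon chains.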